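A few compounds are considered here, and "the series" means these few. Any claim that something is new, unique, unknown or untested is made for them only; others in the source may bear on it.

Working notes on the series, read in an ADME assay on microsomes from liver (Rattus norvegicus) for metabolic stability; on this read-out higher numbers stand for fast clearance and lower numbers for slow clearance. Compound 1 `Cc1ccc(NC(=O)c2cc(Oc3ccc(S(C)(=O)=O)cc3)cc(OC(C)C)c2)nc1` gives 97 mL/min/kg. Within the data shown here, compound 2 `CC(C)Oc1cc(Oc2ccc(S(C)(=O)=O)cc2)cc(-c2cccc(=O)[nH]2)c1` gives 349 mL/min/kg, the higher of the two numbers so far.

Compound 3 `CC(C)Oc1cc(Oc2ccc(S(C)(=O)=O)cc2)cc(-c2cncc(=O)[nH]2)c1` keeps the shared core of compound 2 and changes only the group on an aromatic carbon, meta to an isopropoxy group: a group of 7 heavy atoms (4 carbon, 2 nitrogen, 1 oxygen; one six-membered aromatic ring with 2 hetero atoms) in place of a group of 7 heavy atoms (5 carbon, 1 nitrogen, 1 oxygen; one six-membered aromatic ring with 1 hetero atom), on an aromatic carbon. The entering group still holds one six-membered aromatic ring, now with 2 hetero atoms.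

Among the measured compounds shown here, the only measured step that bears on this is a 3.6-fold higher number from compound 1 to compound 2 (0.56 log units; beyond the scatter), modest and beyond the scatter. It acted on the same aromatic carbon but exchanged groups of unequal heavy-atom count, so it gives no direct measure of the present exchange. For the measured compounds named here, no measured pair covers this exchange itself. A small step is therefore expected in this assay, towards a lower number if anything, and not clearly beyond the scatter. The expected step is a 1.4-fold lower number from compound 2 to compound 3 (0.14 log units; within the scatter). The estimate for compound 3 is 250 mL/min/kg, with an expected range from 120 mL/min/kg to 470 mL/min/kg.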

Compound 3, clearance: 61 mL/min/kg
For compound 3 the middle estimate is 4.1-fold (0.61 log units) above the measured one, outside the stated range (below it).
By their numbers in this assay, from the lowest: compounds 3 and 1 (each within the scatter of the next); then compound 2.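

In this assay the place on the aromatic carbon, meta to an isopropoxy group, responds to a change inside the ring even when the heavy-atom count stays the same: one more hetero atom in the six-membered aromatic ring gives a 5.7-fold lower number from compound 2 to compound 3 (0.76 log units; beyond the scatter) and moves the number beyond the scatter, which the unequal exchange between compound 1 and compound 2 could not show. Heavy-atom count alone therefore does not set the number at this place, since the group of 7 heavy atoms in compound 3 stands level with the group of 10 heavy atoms in compound 1 (a 1.6-fold lower number from compound 1 to compound 3 (0.20 log units; within the scatter)), while the equally sized group in compound 2 does not. Nothing on hand explains why the added hetero atom goes with this step.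

From the compounds shown here alone, it remains open whether the low number of compound 3 holds when the entering ring carries a further group, such as a fluorine or an amine. Going by these compounds, it is also open whether the same ring exchange gives a step of this size with a longer chain in place of the isopropoxy group.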